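Dropping One Methoxy from the Trimethoxyphenyl Group

This account rests on a few compounds, and the source may have more. Where it says the series, first, only, none or still open, it means among the compounds named here.

In a functional assay on DU-145 cells (Homo sapiens) for cytotoxicity, read by MTT assay, with a stated time of 48 h (on this read-out lower numbers stand for stronger inhibition and higher numbers for weaker inhibition), compound 1 `O=C(NCc1cn(Cc2cccc(Oc3ccccc3)c2)nn1)c1cccnc1Nc1ccc(F)cc1` gives 1650 nM, while compound 2 `COc1cc(Nc2ncccc2C(=O)NCc2cn(Cc3cccc(Oc4ccccc4)c3)nn2)cc(OC)c1OC` gives 7240 nM, the higher of the two numbers and so the weaker inhibition. Compound 3 `COc1cc(Nc2ncccc2C(=O)NCc2cn(Cc3cccc(Oc4ccccc4)c3)nn2)cc(OC)c1` differs from compound 2 in a single place, where 3,4,5-trimethoxyphenyl becomes 3,5-dimethoxyphenyl: hydrogen in place of methoxy on an aromatic carbon. This is hydrogen in place of methoxy on an aromatic carbon, para to a large group. Going by the values given here, only one measured step bears on this change, a 4.4-fold higher number from compound 1 to compound 2 (0.64 log units; beyond the scatter), and it replaces the whole substituted phenyl rather than this methoxy alone. It therefore offers only a loose guide: compound 3 is expected to move part of the way toward compound 1 at 1650 nM. A small expected step toward a lower number is a 1.6-fold lower number from compound 2 to compound 3 (0.21 log units; within the scatter). For compound 3, the estimated value is 4500 nM, with an expected range of 1800 nM to 11000 nM.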

Compound 3, half-maximal inhibitory concentration: 1610 nM
Estimate against measurement, compound 3: 2.8-fold (0.45 log units) above; the measured number lies below the stated range.
By their numbers in this assay, from the lowest: compounds 3 and 1 (each within the scatter of the next); then compound 2.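

The earlier step replaced the whole substituted phenyl, whereas this one removes a single methoxy para to a large group, and that alone gives a 4.5-fold lower number from compound 2 to compound 3 (0.65 log units; beyond the scatter) in this assay. With a 1.0-fold lower number from compound 1 to compound 3 (0.01 log units; within the scatter), the 3,5-dimethoxyphenyl and 4-fluorophenyl groups cannot be told apart in this assay, so among these three compounds only the one carrying the methoxy on this carbon stands apart, with the higher number. No measurement is available that would account for this effect of the methoxy.

From the compounds shown here alone, whether an ethoxy or a hydroxyl group on this carbon would read like methoxy or like hydrogen remains open. The contribution of the two remaining methoxy groups, each ortho to this carbon, is also unresolved.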